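Swapping acetyl for 1,1-dimethylpropyl in compound 1

The source may report more compounds than this note shows. Statements on the series, on what has been measured and on what is new or still open speak of the compounds shown alone.

Values in a functional assay on L5178Y cells (Mus musculus) for cytotoxicity, read by MTT assay; on this read-out lower numbers stand for stronger inhibition and higher numbers for weaker inhibition:
- Compound 1 `CC(=O)c1ccc(OCCCCN2CCN(c3ncccn3)CC2)cc1`: > 100 nM (a limit, not a number)
- Compound 2 `CC(=O)c1ccc(OCCCCN2CCN(c3ccccn3)CC2)cc1`: 63.7 nM

Compound 1 has no exact position on this scale, only a limit: the limit of > 100 nM in this assay, at which 1 of the 2 values shown sits. Compound 3 `CCC(C)(C)c1ccc(OCCCCN2CCN(c3ncccn3)CC2)cc1` differs from it at one place, (1,1-dimethylpropyl in place of acetyl on an aromatic carbon), with 1,1-dimethylpropyl in place of acetyl on an aromatic carbon. Among the measured compounds shown here, the only measured step, an at least 1.5-fold lower number from compound 1 to compound 2 (0.19 log units; that floor lies within the scatter), places pyridin-2-yl in place of pyrimidin-2-yl on an amine nitrogen in a ring. That is another part of the molecule, so it says little about the acetyl, and no step beyond the scatter is expected in this assay, in either direction. The expected step is a number no higher from compound 1 to compound 3 (the limit leaves the size open). For compound 3 the estimated value is 100 nM, with an expected range from 40 nM to 250 nM.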

Compound 3, half-maximal inhibitory concentration: 46.4 nM
Beside the measured number, compound 3's estimate is 2.2-fold (0.33 log units) above it, within the range that was stated.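

In this assay, this change at the aromatic carbon gives a step that clears the scatter, which the earlier ring swap on the amine nitrogen did not: an at least 2.1-fold lower number from compound 1 to compound 3 (0.33 log units; beyond the scatter). The acetyl, with its double bond and hydrogen-bond acceptor, is therefore not needed for a number this low, as 1,1-dimethylpropyl has neither and still gives the lower value. Compound 1 stands only as a limit, so the printed step is a floor and its full size stays open: the limit of > 100 nM in this assay, at which 1 of the 3 values shown sits.

The compounds shown leave open how other groups at this place would fare, such as a methyl, a methoxy or a carboxylic acid. They also leave open whether 1,1-dimethylpropyl and pyridin-2-yl, placed together on one molecule, would lower the number further.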